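The source may report more compounds than this note shows. Statements on the series, on what has been measured and on what is new or still open speak of the compounds shown alone.

Compound 2 `Cc1nn(-c2ncnc3nc[nH]c23)c2c1C(OCc1ccc(F)cc1)CC(=O)N2` gives 1 nM in a functional assay on HEK293 cells for agonist activity at G-protein coupled receptor 39 (Homo sapiens), read by scintillation proximity assay and inositol phosphate accumulation, with a stated time of 75 min, in the presence of a further agent that is not named here (on this read-out higher numbers stand for an effect only at larger amounts of compound and lower numbers for an effect already at smaller amounts), the lower of the two numbers measured; compound 1 `Cc1nn(-c2ncnc3nc[nH]c23)c2c1C(C(=O)N(C)c1nccs1)CC(=O)N2` gives 18 nM, and the step is an 18-fold lower number from compound 1 to compound 2 (1.26 log units; beyond the scatter). Compound 3 `Cc1nn(-c2ncnc3nc[nH]c23)c2c1C(OCc1ccccc1C#N)CC(=O)N2` differs from compound 2 by 2-cyanophenyl in place of 4-fluorophenyl on a saturated chain carbon bound to an oxygen on a saturated carbon. Among the compounds with values here, the only measured step concerns another part of the molecule, so no measured step bears directly on this change, and a step within the scatter is the plain expectation. Compound 3 is therefore estimated at 2 nM, between 0.5 nM and 8 nM, which means an expected step of a 2.0-fold higher number from compound 2 to compound 3 (0.30 log units; within the scatter).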

Compound 3, half-maximal effective concentration: 8 nM
Compound 3: the middle estimate sits 4.0-fold (0.60 log units) below what was measured; the range from low to high includes it.
By their numbers in this assay, from the lowest: compound 2; then compound 3; then compound 1.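

Exchanging 4-fluorophenyl for 2-cyanophenyl gives an 8.0-fold higher number from compound 2 to compound 3 (0.90 log units; beyond the scatter) and so shows that the ring at the end of this chain is not a neutral place in the molecule. The (2-cyanobenzyl)oxy group still compares well with methyl(1,3-thiazol-2-yl)carbamoyl, with a 2.3-fold lower number from compound 1 to compound 3 (0.35 log units; beyond the scatter) as the step, so only part of the gain seen with (4-fluorobenzyl)oxy remains. As far as these compounds go, how a plain benzyl group, or a carboxylic acid on this ring, would read stays open. Nothing measured here explains why the two rings differ.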